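Swapping the aryl neighbour in a trimethoxybenzoyl pyrrole series

The source may hold more compounds than are shown below. What is called first, only, known or untested is meant among the compounds shown, and "the series" means these compounds.

Of the compounds shown here, three have been measured in a functional assay on MCF7 cells (Homo sapiens) for cytotoxicity, read by MTT assay, with a stated time of 96 h; a higher number here means a weaker inhibitor, a lower number a stronger inhibitor. Compound 1 `COc1cc(C(=O)c2cn(-c3ccc(Cl)cc3)cc2-c2ccccc2)cc(OC)c1OC` gives 140 nM, compound 2 `COc1cc(C(=O)c2cn(-c3ccc([N+](=O)[O-])cc3)cc2-c2ccccc2)cc(OC)c1OC` gives 4000 nM, and compound 3 `COc1cc(C(=O)c2cn(-c3ccccc3)cc2-c2ccc(Cl)cc2)cc(OC)c1OC` gives 290 nM. Compound 3 thus stands second highest of the values shown, nearest to compound 1 and furthest from compound 2. Within the data shown here, the only step between measured compounds, a 29-fold higher number from compound 1 to compound 2 (1.46 log units; beyond the scatter), concerns a different ring of the molecule and so does not bear directly on the change to compound 4 `COc1ccc(Br)cc1-c1cn(-c2ccccc2)cc1C(=O)c1cc(OC)c(OC)c(OC)c1`, which is 5-bromo-2-methoxyphenyl in place of 4-chlorophenyl on an aromatic carbon. With no measured guide for this position, only a modest move in this assay is expected, most likely toward a higher number, a 1.7-fold higher number from compound 3 to compound 4 (0.24 log units; within the scatter). Compound 4 is therefore estimated at 500 nM, within 150 nM to 2000 nM.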

Compound 4, half-maximal inhibitory concentration: 2200 nM
For compound 4 the middle estimate is 4.4-fold (0.64 log units) below the measured one; the measured number lies above the stated range.
By their numbers in this assay, from the lowest: compound 1; then compound 3; then compounds 4 and 2 (each within the scatter of the next).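

This position responds to the aryl group it carries: in this assay, 5-bromo-2-methoxyphenyl in place of 4-chlorophenyl gives a 7.6-fold higher number from compound 3 to compound 4 (0.88 log units; beyond the scatter). Among these compounds, it is the first step read at this position, as the only earlier step concerned the aryl group on the ring nitrogen. Nothing available accounts for this change in potency.

The bromine and methoxy group enter together, so their separate contributions remain unresolved. Going by these compounds, how an amine or a carboxylic acid on this aryl group would fare also remains open.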